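The source may hold more compounds than are shown below. What is called first, only, known or untested is meant among the compounds shown, and "the series" means these compounds.

Working notes on a four-compound series built on one shared core. Compound 1 `COc1ccc(-c2cn(/N=C/c3cc4ccccc4nc3Cl)c(N)n2)cc1` was run in a functional assay on MDA-MB-231 cells (Homo sapiens) for cytotoxicity, read by MTT assay, with a stated time of 48 h; a higher number here means a weaker inhibitor, a lower number a stronger inhibitor. For compound 1 the reading is a limit of the assay, > 50000 nM. Compound 2 `COc1ccc(-c2cn(/N=C/c3cc4cc(C)ccc4nc3Cl)c(N)n2)cc1` carries methyl in place of hydrogen on an aromatic carbon; in this assay compound 2 gives 23600 nM, and the step is an at least 2.1-fold lower number from compound 1 to compound 2 (0.32 log units; beyond the scatter). Compound 3 `Nc1nc(-c2cccs2)cn1/N=C/c1cc2ccccc2nc1Cl` differs from compound 1 by thiophen-2-yl in place of 4-methoxyphenyl on an aromatic carbon. For compound 3 too the reading in this assay is a limit, > 50000 nM. The step that the two limits leave unreadable from compound 1 to compound 3 cannot be read because the limit of > 50000 nM in this assay, at which 2 of the 3 values shown sit, caps both compounds. Compound 4 `Cc1ccc2nc(Cl)c(/C=N/n3cc(-c4cccs4)nc3N)cc2c1` is not yet measured; it differs from compound 3 by methyl in place of hydrogen on an aromatic carbon, the same change as that from compound 1 to compound 2, at the same place on the core. Going by the values given here, the only measured instance of this change is an at least 2.1-fold lower number from compound 1 to compound 2 (0.32 log units; beyond the scatter). On that basis an at least 1.2-fold lower number from compound 3 to compound 4 (0.09 log units; that floor lies within the scatter) is estimated. In this assay compound 4 is expected to give 40000 nM, between 12000 nM and 200000 nM, with a real chance that only a limit is again recorded.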

Compound 4, half-maximal inhibitory concentration: > 50000 nM
Compound 4: only a limit was reported; the forecaster's own chance of this, stated with the estimate: 50%; at least 1.2-fold (0.09 log units) between middle value and limit.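

In this assay compound 4 gives > 50000 nM, which is a limit of the assay and not a number. Going by these compounds alone, the methyl in place of hydrogen therefore shows no readable effect on the thiophen-2-yl core, and the step on that core cannot be read, because both compounds are capped: the limit of > 50000 nM in this assay, at which 3 of the 4 values shown sit. So the single readable methyl step, on the 4-methoxyphenyl core, is neither confirmed nor contradicted on the second core, and the one new readable comparison is a different change, thiophen-2-yl in place of 4-methoxyphenyl with the methyl present, an at least 2.1-fold higher number from compound 2 to compound 4 (0.32 log units; beyond the scatter).

As far as these compounds go, whether the methyl step carries from one core to the other remains open, as does the size of any effect of the thiophen-2-yl group without the methyl. The compounds shown also leave open what a longer chain such as ethyl, or an amine or a carboxylic acid, on the same aromatic carbon would give in this assay.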